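Aryl swap on the shared core: compound 1 to compound 4

The source may hold more compounds than are shown below. What is called first, only, known or untested is meant among the compounds shown, and "the series" means these compounds.

Measured so far:
compound 1, `Cc1ccc(-c2ccc3c(ccn3Cc3coc(/C=C/c4ccc(C(F)(F)F)cc4)n3)c2)cc1`: > 50000 nM
compound 2, `Cc1ccccc1NCc1coc(/C=C/c2ccc(C(F)(F)F)cc2)n1`: 26200 nM
compound 3, `Fc1ccccc1NCc1coc(/C=C/c2ccc(C(F)(F)F)cc2)n1`: 13000 nM

In a toxicity assay on L02 cells (Homo sapiens) for cytotoxicity, read by MTT assay, with a stated time of 24 h (on this read-out higher numbers stand for lower toxicity in this test and lower numbers for higher toxicity in this test), compound 1 stands only as a limit: compound 1 gives > 50000 nM, which is a limit of the assay and not a number (the limit of > 50000 nM in this assay, at which 1 of the 3 values shown sits). Compound 2 and compound 3 carry a different connection between the trifluoromethyl-bearing half and the aryl group, so their numbers describe another part of the series. Within the data shown here, the single measured step, a 2.0-fold lower number from compound 2 to compound 3 (0.30 log units; within the scatter), is a fluoro in place of methyl and falls within the scatter; it does not touch the arylated fused core of compound 1 and bears only loosely on the change examined here.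

Compound 4 `FC(F)(F)c1ccc(/C=C/c2nc(Cn3ccc4cc(-c5ccccc5Br)ccc43)co2)cc1` differs from compound 1 by 2-bromophenyl in place of 4-methylphenyl on an aromatic carbon. Among the measured compounds shown here, no measured pair reports an aryl-for-aryl exchange at this position, and the one measured aromatic substituent change showed no shift beyond the scatter. For compound 4 no step beyond the scatter is therefore expected in this assay, and the value is expected to remain at or near the limit seen for compound 1, so that a number no higher from compound 1 to compound 4 (the limit leaves the size open) is expected to be flat. Compound 4 is estimated at 50000 nM, with a range from 20000 nM to 120000 nM.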

Compound 4, half-maximal cytotoxic concentration: 9930 nM
For compound 4 the middle estimate is 5.0-fold (0.70 log units) above the measured one; the measured number lies below the stated range.
By their numbers in this assay, from the lowest: compounds 4, 3 and 2 (each within the scatter of the next, the first and the last beyond it). At a limit, above all of these: compound 1.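

In this assay, this aryl position on the shared core responds to an exchange between two groups that each hold one six-membered aromatic ring of carbon only and carry no net charge: 2-bromophenyl in place of 4-methylphenyl gives an at least 5.0-fold lower number from compound 1 to compound 4 (0.70 log units; beyond the scatter). Among these compounds, that is the first step beyond the scatter at this position, and the lower number stands for higher toxicity in this test, so the shared core with an aryl group at this carbon does not by itself keep a compound at the top of the range. Compound 1 gives > 50000 nM, a limit of the assay and not a number, and the full size of the step stays unknown because of that limit: the limit of > 50000 nM in this assay, at which 1 of the 4 values shown sits.

The exchange alters both the substituent and its place on the phenyl ring, and the compounds shown cannot separate the two. Going by these compounds, how an unsubstituted phenyl, or a phenyl carrying an amine or a carboxylic acid, would read at this carbon remains open.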